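Ester to amide exchange at the proline terminus

This account rests on a few compounds, and the source may have more. Where it says the series, first, only, none or still open, it means among the compounds named here.

Measured so far, in a functional assay on HEK293 cells for agonist activity at Vasopressin V2 receptor (Homo sapiens), read by a luciferase reporter and cAMP accumulation; a lower number here means that less compound is needed, a higher number that more compound is needed for the effect:
- compound 1 `Cc1cc(C(=O)N2CCCCc3ccccc32)ccc1CNC(=O)N1CCC[C@H]1C(=O)OC(C)C`: 950 nM
- compound 2 `Cc1cc(C(=O)N2CCCCc3ccccc32)ccc1CNC(=O)N1CCC[C@H]1C(=O)OC(C)(C)C`: 390 nM

Compound 2 holds the lowest of the two numbers in this assay; its nearest neighbour is compound 1, and the gap between them is a 2.4-fold lower number from compound 1 to compound 2 (0.39 log units; beyond the scatter), a modest change brought about by methyl in place of hydrogen on a saturated chain carbon bound to an oxygen next to a carbonyl group and two saturated chain carbons.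

Compound 3 `CCN(CC)C(=O)[C@@H]1CCCN1C(=O)NCc1ccc(C(=O)N2CCCCc3ccccc32)cc1C` is the next point. It differs from compound 2 by diethylamino in place of tert-butoxy on a carbonyl carbon. Going by the values given here, the one measured step, a 2.4-fold lower number from compound 1 to compound 2 (0.39 log units; beyond the scatter), concerns only the alkyl part of the ester and leaves the ester itself intact, so there is no direct precedent for exchanging the tert-butoxy for diethylamino. The expectation is therefore weak and centred near compound 2, with a wide spread to either side. For compound 3 the value in this assay is expected at 600 nM, within 150 nM to 2500 nM. The step this estimate implies is a 1.5-fold higher number from compound 2 to compound 3 (0.19 log units; within the scatter), expected to stay within the scatter.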

Compound 3, half-maximal effective concentration: 350 nM
Estimate against measurement, compound 3: 1.7-fold (0.23 log units) above; the range from low to high includes it.
By their numbers in this assay, from the lowest: compounds 3 and 2 (each within the scatter of the next); then compound 1.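

Working notes on the carbonyl carbon at the proline terminus: in this assay, diethylamino in place of tert-butoxy gives a 1.1-fold lower number from compound 2 to compound 3 (0.05 log units; within the scatter) and so leaves the number where it was, which shows that among these compounds the ester link is not required to hold this level. Set against the isopropyl ester, the same amide gives a 2.7-fold lower number from compound 1 to compound 3 (0.43 log units; beyond the scatter) and lands beyond the scatter, as does the tert-butyl ester in a 2.4-fold lower number from compound 1 to compound 2 (0.39 log units; beyond the scatter), so compound 1 stands apart from the other two while compounds 2 and 3 cannot be told apart in this read-out. Nothing measured here accounts for the match between the tert-butyl ester and the diethylamide or for the gap to the isopropyl ester.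

Still open, as far as these compounds go, is how far this tolerance extends on the same carbonyl carbon, for example to dimethylamino, to a cyclic amine such as pyrrolidin-1-yl, or to the free carboxylic acid. Ethylamino, which brings an amide hydrogen, would also show whether the level of compound 3 depends on both ethyl groups on the nitrogen.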